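A 2-Carboxyethyl Group Replaces the Bromophenyl Substituent

A few compounds are considered here, and "the series" means these few. Any claim that something is new, unique, unknown or untested is made for them only; others in the source may bear on it.

Of the compounds shown here, three sharing one core have been measured in a functional assay on K562 cells (Homo sapiens) for cytotoxicity, read by trypan blue exclusion, with a stated time of 96 h (a higher number here means a weaker inhibitor, a lower number a stronger inhibitor), and they differ only in the substituent on the nitrogen. Compound 1 (`COC(=O)C(C)(C)Nc1cc(CS(=O)(=O)/C=C/c2c(OC)cc(OC)cc2OC)ccc1OC`) gives 800 nM there, compound 2 (`COC(=O)C(Nc1cc(CS(=O)(=O)/C=C/c2c(OC)cc(OC)cc2OC)ccc1OC)c1ccccc1`) gives 30 nM there, and compound 3 (`COC(=O)C(Nc1cc(CS(=O)(=O)/C=C/c2c(OC)cc(OC)cc2OC)ccc1OC)c1ccc(Br)cc1`) gives 200 nM as the middle number of the three. Compound 4 (`COc1cc(OC)c(/C=C/S(=O)(=O)Cc2ccc(OC)c(NCCC(=O)O)c2)c(OC)c1`) has not yet been measured. Its difference from compound 3 (2-carboxyethyl in place of (4-bromophenyl)(methoxycarbonyl)methyl on a nitrogen on an aromatic ring) puts 2-carboxyethyl in place of (4-bromophenyl)(methoxycarbonyl)methyl on a nitrogen on an aromatic ring. Changes at this nitrogen have already moved the numbers: the step of a 27-fold lower number from compound 1 to compound 2 (1.43 log units; beyond the scatter) is large, while the steps of a 4.0-fold lower number from compound 1 to compound 3 (0.60 log units; beyond the scatter) and a 6.7-fold higher number from compound 2 to compound 3 (0.82 log units; beyond the scatter) are modest. Yet no measured compound carries 2-carboxyethyl, and all three keep the methoxycarbonyl group, so these steps show sensitivity without giving a direction. For compound 4 the expected step is a 1.5-fold higher number from compound 3 to compound 4 (0.18 log units; within the scatter) and no shift beyond the scatter is assumed, with wide uncertainty. Compound 4 is expected in this assay at 300 nM (range 60 nM to 1500 nM).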

Compound 4, half-maximal inhibitory concentration: 5000 nM
Beside the measured number, compound 4's estimate is 17-fold (1.22 log units) below it; the whole stated range lies below it.
By their numbers in this assay, from the lowest: compound 2; then compound 3; then compound 1; then compound 4.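

In this assay, the 2-carboxyethyl group on the nitrogen makes compound 4 the weakest of the four, with a 25-fold higher number from compound 3 to compound 4 (1.40 log units; beyond the scatter), a 170-fold higher number from compound 2 to compound 4 (2.22 log units; beyond the scatter) and a 6.3-fold higher number from compound 1 to compound 4 (0.80 log units; beyond the scatter). Going by these compounds alone, this is the first compound here in which the methoxycarbonyl group is absent, and the position proves able to lose far more activity than the earlier esters showed. Compound 1 also has no ring on this substituent, and its step to compound 4 is the smallest of the three, though still beyond the scatter; nothing available gives a reason for these differences.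

The shown compounds do not separate the carboxylic acid from the change in chain and ring. A 2-(methoxycarbonyl)ethyl or a carboxy(phenyl)methyl group on this nitrogen would pull these two changes apart.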